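The compounds below may be only part of what the source reports. "The series", "measured", "known", "first", "only" and "open" are said of these compounds alone.

Measured compounds:
- compound 1, `Cc1c(C(=O)CSc2ccc(F)cc2)[n+]([O-])c2ccccc2[n+]1[O-]`: 50 ug/mL
- compound 2, `CC(=O)NCCSCC(=O)c1c(C)[n+]([O-])c2ccccc2[n+]1[O-]`: "not determined" (no result reported)

Compound 1 and compound 2 share the same core. In an ADME assay on Vero cells (Chlorocebus sabaeus) for cytotoxicity, read by MTT assay, with a stated time of 72 h (a higher number here means that more compound is tolerated, a lower number that less compound is tolerated), compound 1 gives 50 ug/mL. For compound 2 this assay reports "not determined" (no result reported), so there is no single number on which compound 2 stands, and its place cannot be told from what was measured.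

Compound 3, `Cc1c(C(=O)CSCCNC(=O)c2ccc(F)cc2)[n+]([O-])c2ccccc2[n+]1[O-]`, differs from compound 2 in one place: 4-fluorophenyl in place of methyl on a carbonyl carbon. Among the compounds with values here, no step between measured compounds covers this change, and compound 2 itself has no number, so nothing can be said about the size or direction of the step in this assay beyond the scatter; the only anchor is compound 1, which also carries a 4-fluorophenyl group and gives 50 ug/mL.

On that basis compound 3 is expected to fall near 50 ug/mL, within a range of 15 ug/mL to 150 ug/mL.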

Compound 3, half-maximal cytotoxic concentration: > 100 ug/mL
Compound 3: only a limit was reported; the forecaster's own chance of this, stated with the estimate: 30%; middle value at least 2.0-fold (0.30 log units) from the limit.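

No step can be read from compound 2 to compound 3: in this assay compound 2 has no number, and compound 3 has only a limit, > 100 ug/mL. The compounds shown leave open what replacing methyl with 4-fluorophenyl on a carbonyl carbon does in this assay.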